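Ester to Acid with Added Chlorine on the Aryl Ether

The source may report more compounds than this note shows. Statements on the series, on what has been measured and on what is new or still open speak of the compounds shown alone.

Compound 1, `COC(=O)c1ccc(OCCCCOc2ccc(C(=O)CC3CCCC3)c(O)c2C)cc1`, gives 22% in an assay on HEK293 cells for positive allosteric modulation of metabotropic glutamate receptor 3 (Rattus norvegicus), read by thallium flux, with a stated time of 2.5 min; on this read-out lower numbers stand for smaller maximal responses and higher numbers for larger maximal responses.
Compound 2, `Cc1c(OCCCCOCOc2ccc(C(=O)O)cc2)ccc(C(=O)CC2CCCC2)c1O`, gives 46.9% in this assay.
Compound 3, `COC(=O)c1ccc(OCCCCOc2ccc(C(=O)CC(C)C)c(O)c2C)cc1`, gives 22.7% in this assay.

Compound 3 stands second highest of the three numbers. Its nearest neighbour is compound 1, whose number lies within the scatter of its own; compound 2 lies above it beyond the scatter. The step of a number 0.7 percentage points higher from compound 1 to compound 3 (within the scatter) shows that exchanging cyclopentyl for isopropyl on the saturated chain carbon bound to the carbonyl carbon moved the read-out hardly at all.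

Compound 4, `Cc1c(OCCCCOc2ccc(C(=O)O)c(Cl)c2)ccc(C(=O)CC(C)C)c1O`, differs from compound 3 in one place: 4-carboxy-3-chlorophenyl in place of 4-(methoxycarbonyl)phenyl on an oxygen on a saturated carbon. Among the compounds with values here, the only measured step that bears on this is a number 24.9 percentage points higher from compound 1 to compound 2 (beyond the scatter), in which the 4-(methoxycarbonyl)phenyl group likewise gave way to a group carrying a free carboxy group, with a modest rise. Within the data shown here, no measured pair shows what the chlorine atom contributes, so that part of the change carries no evidence either way.

Compound 4 is therefore expected to show a modest rise, to 40% in this assay, most likely between 25% and 55%. The expected step is a number 17.3 percentage points higher from compound 3 to compound 4 (beyond the scatter).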

Compound 4, largest response reached (reported as percent of maximum), in percent of the reference or control that the assay uses: 49.5%
For compound 4 the middle estimate is 9.5 percentage points below the measured one; measured number inside the range.
By their numbers in this assay, from the lowest: compounds 1 and 3 (each within the scatter of the next); then compounds 2 and 4 (each within the scatter of the next).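

In this assay, the change at this oxygen-bound aryl group gives a number 26.8 percentage points higher from compound 3 to compound 4 (beyond the scatter), so replacing 4-(methoxycarbonyl)phenyl with 4-carboxy-3-chlorophenyl produces a modest rise beyond the usual scatter. Until now, a rise on leaving the 4-(methoxycarbonyl)phenyl group had been seen only in a compound with cyclopentyl on the saturated chain carbon bound to the carbonyl carbon; it now appears with isopropyl there too, so among these compounds it is not confined to one of the two groups. Nothing in the available data explains why the maximal response rises with this change.

The free carboxy group and the chlorine entered together in a single step, so the compounds shown cannot assign the rise to either one, and a 4-carboxyphenyl partner for compound 3 would be needed to separate them. On these data alone, it also remains open how the read-out would respond to fluorine or a methyl group in place of the chlorine, or to a primary amide or a tetrazole in place of the carboxy group.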